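This account rests on a few compounds, and the source may have more. Where it says the series, first, only, none or still open, it means among the compounds named here.

Measured so far, in an assay on CHO cells for displacement of a labelled ligand from adenosine receptor A1 (Homo sapiens), read by scintillation counting, with a stated time of 90 min; a lower number here means a stronger inhibitor, a higher number a weaker inhibitor: compound 1 `CCOc1ccc(-c2c(C#N)c(N)nc(SCc3ccn[nH]3)c2C#N)cc1` gives 21 nM; compound 2 `N#Cc1c(N)nc(SCc2cccc(C(N)=O)c2)c(C#N)c1-c1ccc(OCC2CC2)cc1` gives 83 nM; compound 3 `C=CCOc1ccc(-c2c(C#N)c(N)nc(SCc3ccn[nH]3)c2C#N)cc1` gives 44 nM.

Compound 2 has the highest number of the three. Against compound 3 the gap is within the scatter, so the two cannot be ordered; against compound 1 the gap is beyond the scatter, and compound 1 gives the lower number. Among the compounds with values here, the only step between two measured compounds that differ in one place is a 2.1-fold higher number from compound 1 to compound 3 (0.32 log units; beyond the scatter), and it concerns the group on the oxygen of the aromatic ring, not the group on the sulfur.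

Compound 4 `N#Cc1c(N)nc(SCC2=NCCN2)c(C#N)c1-c1ccc(OCC2CC2)cc1` differs from compound 2 at the sulfur side: a group of 5 heavy atoms (3 carbon, 2 nitrogen; one five-membered non-aromatic ring with 2 hetero atoms) in place of a group of 9 heavy atoms (7 carbon, 1 nitrogen, 1 oxygen; one six-membered aromatic ring of carbon only), on a saturated chain carbon bound to a sulfur. Within the data shown here, no measured step covers this exact change. What the numbers show is that compounds 1 and 3, which carry a five-membered ring with two nitrogens on the chain carbon bound to the sulfur, give lower numbers than compound 2, which carries the carbamoylphenyl. Compound 4 brings in a five-membered ring with two nitrogens, though a non-aromatic one, so a modest move in this assay toward a lower number is expected, roughly a 2.1-fold lower number from compound 2 to compound 4 (0.32 log units; beyond the scatter). Compound 4 is therefore estimated at 40 nM, with a range from 10 nM to 160 nM.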

Compound 4, inhibition constant: 483 nM
Beside the measured number, compound 4's estimate is 12-fold (1.08 log units) below it, outside the stated range (above it).
By their numbers in this assay, from the lowest: compound 1; then compounds 3 and 2 (each within the scatter of the next); then compound 4.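

In this assay, within the data shown here, the group on the saturated chain carbon bound to the sulfur proves to matter: with the rest of the molecule unchanged, putting a five-membered non-aromatic ring with 2 hetero atoms in place of 3-carbamoylphenyl gives a 5.8-fold higher number from compound 2 to compound 4 (0.76 log units; beyond the scatter) and is the first measured step at this place. The earlier step concerned only the group on the oxygen of the aromatic ring, whereas this one shows that, on the rest of compound 2, a five-membered ring with two nitrogens does not by itself bring a lower number, and that 3-carbamoylphenyl is the better of these two groups at this place. Nothing given here bears on why the number rises at this place.

The compounds shown leave open whether the aromatic five-membered ring of compound 1 would give a lower number than 3-carbamoylphenyl if the group on the oxygen were held the same, since no pair isolates that change. They also leave open how a plain phenyl, a pyridine ring or an aminomethyl group would read on this chain carbon, and so whether the carbamoyl group or the six-membered aromatic ring carries the difference.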